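Moving the sulfur position in a thiophene on the shared core

The source may report more compounds than this note shows. Statements on the series, on what has been measured and on what is new or still open speak of the compounds shown alone.

Measured compounds in an assay on HeLa cells for displacement of a labelled ligand from adenosine receptor A3 (Homo sapiens), with a stated time of 180 min, tested at 10 uM; a higher number here means more inhibition at the concentration tested (going by the name of the read-out), a lower number less inhibition:
Compound 1 `CCCOC(=O)C1=C(C)NC(=O)NC1c1ccco1` gives 2%.
Compound 2 `CCOC(=O)C1=C(C)N(C)C(=O)NC1c1cccs1` gives 6%.
Compound 3 `CC1=C(C(=O)OC(C)C)C(c2cccs2)NC(=O)N1C` gives 18%.

Compound 2 stands second highest of the three numbers; its nearest neighbour is compound 1, a value within the scatter, and its furthest is compound 3, which lies beyond the scatter above it. Among the compounds with values here, the one step with a single change is a number 12 percentage points higher from compound 2 to compound 3 (beyond the scatter), and it concerns the ester part, not the aromatic ring.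

Compound 4 `CCOC(=O)C1=C(C)N(C)C(=O)NC1c1ccsc1` differs from compound 2 by thiophen-3-yl in place of thiophen-2-yl on a saturated ring carbon. Within the data shown here, no measured pair changes the attachment point of the thiophene, so nothing among the measured steps bears directly on this move; the ester step concerns a different part of the molecule. With no guide, the expectation is a step that stays within the scatter.

Compound 4 is therefore expected to give 7%, with a range from 0% to 18%. That estimate means an expected step of a number 1 percentage points higher from compound 2 to compound 4 (within the scatter), not beyond the scatter.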

Compound 4, a percentage reported as inhibition, at one concentration (the size of the read-out at that concentration, not a potency): 3%
Compound 4: middle estimate off by 4 percentage points, on the high side, within the range that was stated.
By their numbers in this assay, from the lowest: compounds 1, 4 and 2 (each within the scatter of the next); then compound 3.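

In this assay, the swap of thiophen-2-yl for thiophen-3-yl on the saturated ring carbon gives a number 3 percentage points lower from compound 2 to compound 4 (within the scatter), so this read-out cannot tell the two attachment points apart. The sulfur can therefore sit in either place on this ring without a visible effect on the number, at least on the core of compound 2, whereas the ester change gave a number 12 percentage points higher from compound 2 to compound 3 (beyond the scatter). Nothing available here offers an explanation for this result.

Going by these compounds, it remains open whether thiophen-3-yl would give the same number alongside the ester of compound 3. On these data alone, it is also open whether a different group on this ring carbon, such as a phenyl ring carrying an amine, would move the number beyond the scatter.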